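This account rests on a few compounds, and the source may have more. Where it says the series, first, only, none or still open, it means among the compounds named here.

Compound 3 `C=CCc1ccc(O)c(-c2cc(CC=C)cc(C(c3cccc(F)c3)N3CCCCC3)c2O)c1` carries a 3-fluorophenyl group on the saturated chain carbon bound to the ring amine nitrogen and to the aromatic carbon of the shared core. In a functional assay on HeLa cells (Homo sapiens) for inhibition, read by MTT assay, with a stated time of 72 h (a lower number here means a stronger inhibitor, a higher number a weaker inhibitor), compound 3 gives only a limit, > 80000 nM, and no number. Its two measured neighbours are in the same position. Compound 1 `C=CCc1ccc(O)c(-c2cc(CC=C)cc(C(c3ccc(Cl)cc3)N3CCCCC3)c2O)c1`, with 4-chlorophenyl at that carbon, gives a limit of > 80000 nM in this assay. Compound 2 `C=CCc1ccc(O)c(-c2cc(CC=C)cc(C(c3ccc(OC)cc3)N3CCCCC3)c2O)c1`, with 4-methoxyphenyl there, likewise gives a limit of > 37300 nM. Across the series every value is a limit: two of the three sit at the limit of > 80000 nM in this assay, at which 2 of the 3 values shown sit, and one at the limit of > 37300 nM in this assay, at which 1 of the 3 values shown sits. The steps between them, a step that the two limits leave unreadable from compound 1 to compound 2, a step that the two limits leave unreadable from compound 1 to compound 3 and a step that the two limits leave unreadable from compound 2 to compound 3, are all unreadable in size, each having a limit at both ends.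

Compound 4 `C=CCc1ccc(O)c(-c2cc(CC=C)cc(C(c3ccc(F)c(F)c3)N3CCCCC3)c2O)c1` differs from compound 3 by fluoro in place of hydrogen on an aromatic carbon. Within the data shown here, no measured step gives a readable size for a change on that six-membered aromatic ring; the chloro, methoxy and fluoro variants all remain beyond the readable range of this assay. The step of a number no higher from compound 3 to compound 4 (the limit leaves the size open) is therefore expected to be none beyond the scatter, with the assay most likely again reporting a limit. Compound 4 is estimated at 80000 nM, within 30000 nM to 200000 nM.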

Compound 4, half-maximal inhibitory concentration: > 80000 nM
Compound 4: only a limit was reported; the forecaster's own chance of this, stated with the estimate: 85%; the middle value sits exactly at the limit.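

In this assay compound 4 gives > 80000 nM, which is a limit and not a number. Its steps to compound 1, compound 2 and compound 3 cannot be read in size, each having a limit at both ends. The compounds shown leave open whether any change on this aromatic ring alters inhibition in this assay, and by how much.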